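Indazole Ring Attachment on a Piperidine Sulfonamide Core

A few compounds are considered here, and "the series" means these few. Any claim that something is new, unique, unknown or untested is made for them only; others in the source may bear on it.

The study measures, in a functional assay on CHO cells for positive allosteric modulation of muscarinic acetylcholine receptor M5 (Homo sapiens), read by calcium flux (on this read-out lower numbers stand for smaller maximal responses and higher numbers for larger maximal responses), three related compounds and points toward a fourth. Compound 1 `CCN(C(=O)C1CCN(S(=O)(=O)c2ccc3cn[nH]c3c2)CC1)[C@H](C)c1ccccc1` gives 87% in this assay. Compound 2 `CCN(C(=O)C1CCN(S(=O)(=O)c2ccc3[nH]ncc3c2)CC1)[C@H](C)c1ccccc1` differs from compound 1 by 1H-indazol-5-yl in place of 1H-indazol-6-yl on a sulfonyl sulfur; compound 2 gives 86%, and the step of a number 1 percentage points lower from compound 1 to compound 2 (within the scatter). Compound 3 `CCN(Cc1ccccc1Cl)C(=O)C1CCN(S(=O)(=O)c2ccc3cn[nH]c3c2)CC1` differs from compound 1 in the core by 2-chlorobenzyl in place of 1-phenylethyl on an amide-type nitrogen; in this assay compound 3 gives 93%, the step being a number 6 percentage points higher from compound 1 to compound 3 (within the scatter).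

Compound 4 `CCN(Cc1ccccc1Cl)C(=O)C1CCN(S(=O)(=O)c2ccc3[nH]ncc3c2)CC1` is not yet measured. It differs from compound 3 by 1H-indazol-5-yl in place of 1H-indazol-6-yl on a sulfonyl sulfur, and the place, a sulfonyl sulfur whose other neighbour is a sulfonamide nitrogen in a ring, is the same word for word as for the change from compound 1 to compound 2. This change occurs twice among the compounds shown, once measured. Because that one measured step was a number 1 percentage points lower from compound 1 to compound 2 (within the scatter), the expected step from compound 3 to compound 4 is estimated as a number 1 percentage points lower from compound 3 to compound 4 (within the scatter). Compound 4 is thus expected to give about 92% in this assay, with an estimated range from 82% to 102%.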

Compound 4, largest response reached (reported as percent of maximum), in percent of the reference or control that the assay uses: 78%
Estimate against measurement, compound 4: 14 percentage points above; measured number outside the range, below it.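

In this assay, exchanging 1H-indazol-6-yl for 1H-indazol-5-yl on the sulfonyl sulfur gives a step of a number 15 percentage points lower from compound 3 to compound 4 (beyond the scatter), but this step cannot be separated from the one measured for the same change on the core of compound 1: the same change on two cores in this assay, a number 1 percentage points lower (within the scatter) from compound 1 to compound 2 and a number 15 percentage points lower (beyond the scatter) from compound 3 to compound 4, 14 percentage points apart, within the scatter of two such steps. The change to 2-chlorobenzyl on the amide-type nitrogen, with a number 8 percentage points lower from compound 2 to compound 4 (within the scatter), reads the same way when set beside its earlier counterpart: the same change on two cores in this assay, a number 6 percentage points higher (within the scatter) from compound 1 to compound 3 and a number 8 percentage points lower (within the scatter) from compound 2 to compound 4, 14 percentage points apart, within the scatter of two such steps. Among the compounds shown here, the series therefore does not show that the indazole change depends on the core, nor does it show that the change carries over unaltered, as it offers only two cores and one step on each.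

Going by these compounds, it remains open whether the step seen on the core of compound 3 would recur with a plain benzyl or a cyclohexylmethyl group on the amide-type nitrogen. The compounds shown also leave open how a benzimidazole or an indole on the sulfonyl sulfur would behave on either core.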